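Hepatocyte clearance notes: cyano in place of methyl

A few compounds are considered here, and "the series" means these few. Any claim that something is new, unique, unknown or untested is made for them only; others in the source may bear on it.

Measured so far in an ADME assay on cells (Hepatocyte, Rattus norvegicus) for metabolic stability; a lower number here means slower removal, a higher number faster removal of the compound:
- compound 1 `Cc1cc(F)c(CNc2ncc(-c3cccnc3C)c3nncn23)c2c1OCC2`: "not determined" (no result reported)
- compound 2 `Cc1ncccc1-c1cnc(NCc2c(F)cc(C3CC3)c3c2CCO3)n2cnnc12`: "not determined" (no result reported)
- compound 3 `Cc1ncccc1-c1cnc(NCc2c(F)cc(Cl)c3c2CCO3)n2cnnc12`: 9 uL/min

Compound 1 has no number in this assay, its entry reading "not determined" (no result reported), and compound 2 likewise has none, its entry reading "not determined" (no result reported); the only figure in the series belongs to compound 3, which gives 9 uL/min in this assay. Compound 1 therefore stands nowhere on the numbers shown, and no step between measured compounds can be drawn.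

Compound 4 `Cc1ncccc1-c1cnc(NCc2c(F)cc(C#N)c3c2CCO3)n2cnnc12` is the next entry to be measured in this assay. Its difference from compound 1 is cyano in place of methyl on an aromatic carbon.

Among the compounds with values here, with no measured step available, the size and direction of the change from compound 1 to compound 4 in this assay cannot be read from the series; any difference within the usual scatter is as plausible as one beyond it, in either direction. The only anchor is the shared core, which compound 3 also carries.

Compound 4 is expected to give about 10 uL/min in this assay, with a range of 4 uL/min to 25 uL/min, because compound 3 with the same core gives 9 uL/min.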

Compound 4, intrinsic clearance in a liver preparation (reported as CLH), per the amount of preparation that the assay uses in the Hepatocyte assay: 10 uL/min
Compound 4: the middle estimate sits on the measured number at the digits printed, and the stated range covers the measured number.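

Within the data shown here, at this aromatic carbon, the first readable step in the Hepatocyte assay is cyano in place of chloro (a 1.1-fold higher number from compound 3 to compound 4 (0.05 log units; within the scatter)), which lies within the scatter, so the series does not separate these two groups at this position. In a physicochemical assay for lipophilicity, using the shake flask method, in phosphate buffer, measured as octanol-water partition, at pH 7.4 (a lower number here means a more polar compound, a higher number a more lipophilic compound), compound 4 gives 2.2 and compound 1 gives "not determined" (no result reported), so this pair offers no comparison in that assay, and the figure for compound 4 stands alone as a single reference point for the series. Nothing available explains why the two groups read alike in the clearance assay.

Steps involving compound 1 or compound 2 cannot be read, which leaves methyl and cyclopropyl at this position without a figure in the Hepatocyte assay and the comparison of either with cyano or chloro unresolved. Also open, as far as these compounds go, is whether a clearly different group at the same aromatic carbon, such as an amine or a carboxylic acid, would move the number in the Hepatocyte assay beyond the scatter, or whether this position tolerates change more widely than two groups can show.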